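The source may report more compounds than this note shows. Statements on the series, on what has been measured and on what is new or still open speak of the compounds shown alone.

Measured compounds:
Compound 1, `Nc1ncnc2c1c(-c1cnc3[nH]ccc3c1)nn2CCCCCCC(=O)NO`: 7500 nM
Compound 2, `Nc1ncnc2c1c(-c1cnc3[nH]ccc3c1)nn2CCCCCC(=O)NO`: "not determined" (no result reported)

In a functional assay on SNU-423 cells (Homo sapiens) for inhibition, read by MTT assay, with a stated time of 72 h (on this read-out lower numbers stand for stronger inhibition and higher numbers for weaker inhibition), compound 1 gives 7500 nM. Compound 2 carries the hydroxycarbamoyl on a chain one carbon shorter than that of compound 1; in this assay compound 2 gives "not determined" (no result reported), so its standing cannot be told from the data; the only measured point in this series is compound 1, and it shows only modest inhibition.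

Compound 3, `CNC(=O)CCCCCCCn1nc(-c2cnc3[nH]ccc3c2)c2c(N)ncnc21`, is not yet measured. It differs from compound 2 by 2-(methylcarbamoyl)ethyl in place of hydroxycarbamoyl on a saturated chain carbon, five bonds along the chain from an aromatic nitrogen. Among the compounds with values here, with no measured step between any two compounds of this set, the size of the step from compound 2 to compound 3 in this assay can only be guessed, and the direction toward weaker inhibition is taken as more likely than the reverse, resting on compound 1 giving only 7500 nM even with its hydroxycarbamoyl in place.

Compound 3 is therefore expected to give about 20000 nM in this assay, with the estimate spanning 5000 nM to 60000 nM.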

Compound 3, half-maximal inhibitory concentration: 5400 nM
Estimate against measurement, compound 3: 3.7-fold (0.57 log units) above; measured number inside the range.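

In this assay, the result gives a 1.4-fold lower number from compound 1 to compound 3 (0.14 log units; within the scatter), with (methylcarbamoyl)methyl in place of hydroxycarbamoyl on a saturated chain carbon, six bonds along the chain from an aromatic nitrogen. Until now the hydroxycarbamoyl had been seen in one measured compound only, with nothing to set it against; this pair shows that, at this place and on this read-out, the group can be exchanged without the number moving beyond the usual scatter, so the modest inhibition of compound 1 does not depend on it here. Nothing among the data shown explains why the exchange leaves the read-out within the scatter.

Compound 2 has no number in this read-out, so the step from it to compound 3 cannot be read, and the pair gives no view of how chain length alone acts. On these data alone, whether a carboxylic acid or an amine at the end of the chain, or a longer chain carrying the hydroxycarbamoyl, would give a different number in this assay remains open, as does how much of the inhibition would remain with the shared core alone.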